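A few compounds are considered here, and "the series" means these few. Any claim that something is new, unique, unknown or untested is made for them only; others in the source may bear on it.

Three compounds that share one core have so far been examined in a functional assay on MCF7 cells (Homo sapiens) for antiproliferative activity, read by MTT assay, with a stated time of 24 h, tested at 100 uM; a higher number here means a weaker effect of the compound at the concentration tested, a lower number a stronger effect. Within the data shown here, compound 1 `OC(CCn1nc2c(Br)c(Br)c(Br)c(Br)c2n1)c1cccc(Br)c1` gives 1% and compound 2 `OC(CCn1nc2c(Br)c(Br)c(Br)c(Br)c2n1)c1cccc(Cl)c1` gives 0%; the only single-point step between measured compounds, a number 1 percentage points lower from compound 1 to compound 2 (within the scatter), is within the scatter. Compound 3 `C[C@@H](O)CCn1nc2c(Br)c(Br)c(Br)c(Br)c2n1` gives 18%, the highest of the three numbers, lying beyond the scatter above both compound 1 and compound 2.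

Compound 4 `CC(O)CCn1nc2c(Br)c(Br)c(Br)c(Br)c2n1` differs from compound 3 in this way: the two compounds have the same atoms and bonds; at least one stereo element is drawn with a configuration in one of them and without one in the other: 1 of 1 stereo elements differ; a stereocentre at a saturated chain carbon is drawn R in compound 3 and without a configuration in compound 4. Among the measured compounds shown here, no measured step involves a change of this kind; the one step known concerns chloro in place of bromo on an aromatic carbon, a different matter, and it stayed within the scatter. The stereocentre drawn as R in compound 3 is simply drawn without a configuration in compound 4, with the same atoms and bonds throughout. The step expected in this assay is a number 3 percentage points lower from compound 3 to compound 4 (within the scatter), which stays within the scatter. The value estimated for compound 4 is 15%, with a range from 3% to 30%.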

Compound 4, a percentage reported as activity, at one concentration (the size of the read-out at that concentration, not a potency): 57%
Estimate against measurement, compound 4: 42 percentage points below, and the stated range ends below it.
By their numbers in this assay, from the lowest: compounds 2 and 1 (each within the scatter of the next); then compound 3; then compound 4.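

At this carbon, the stereochemical drawing alone goes with a large change in this assay: there is a number 39 percentage points higher from compound 3 to compound 4 (beyond the scatter), a shift towards a weaker effect. Replacing the aryl group on the same carbon with methyl also goes with a large weakening, seen as a number 57 percentage points higher from compound 2 to compound 4 (beyond the scatter) and as a number 56 percentage points higher from compound 1 to compound 4 (beyond the scatter). So this carbon responds strongly both to what it carries and to how it is drawn, and the only difference within the first pair is this: the fact that one of compounds 3 and 4 is drawn with a defined configuration and the other without, at the place where they differ

The compounds shown do not reveal how a compound drawn with the opposite configuration at this carbon would behave, or whether either aryl compound would respond to a defined configuration. They also leave open what an amine or a carboxylic acid in place of the hydroxyl group would do.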